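Amide swap from compound 3 to compound 4

The compounds below may be only part of what the source reports. "The series", "measured", "known", "first", "only" and "open" are said of these compounds alone.

Measured in a functional assay on MCF7 cells (Homo sapiens) for antiproliferative activity, read by MTT assay, with a stated time of 24 h; on this read-out lower numbers stand for stronger inhibition and higher numbers for weaker inhibition:
compound 1 `CCCCc1oc2ccccc2c1C(=O)c1ccc(OCC(N)=O)cc1` gives > 50000 nM
compound 2 `CCCCc1oc2ccccc2c1C(=O)c1ccc(OCC(=O)N2CCOCC2)cc1` gives 34000 nM
compound 3 `CCCCNC(=O)CCCOc1ccc(C(=O)c2c(CCCC)oc3ccccc23)cc1` gives > 50000 nM

Compound 3 stands at a limit, > 50000 nM, and has no number. Compound 1 is also a limit, > 50000 nM. The set rests largely on (the limit of > 50000 nM in this assay, at which 2 of the 3 values shown sit). Only compound 2 gives a number, 34000 nM.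

The next compound is compound 4 `CCCCc1oc2ccccc2c1C(=O)c1ccc(OCCCC(=O)N2CCCC2)cc1`. The change is pyrrolidin-1-yl in place of butylamino on a carbonyl carbon. In short, pyrrolidin-1-yl stands in place of butylamino on a carbonyl carbon.

The closest measured change, a ring amine in place of an open one on a carbonyl carbon, is an at least 1.4-fold lower number from compound 1 to compound 2 (0.16 log units; that floor lies within the scatter). The step of an at least 1.4-fold higher number from compound 2 to compound 3 (0.16 log units; that floor lies within the scatter) points the same way when read in reverse, though it also alters the saturated chain. The step that the two limits leave unreadable from compound 1 to compound 3 gives no size.

For the measured compounds named here, with compound 2 at 34000 nM as the only number, a small move to a lower number is expected, not clearly beyond the scatter. The expected step is an at least 1.2-fold lower number from compound 3 to compound 4 (0.09 log units; that floor lies within the scatter). For compound 4 the estimated value is 40000 nM, with an expected range of 15000 nM to 70000 nM.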

Compound 4, half-maximal inhibitory concentration: 23500 nM
For compound 4 the middle estimate is 1.7-fold (0.23 log units) above the measured one; low and high end bracket the measured number.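

In this assay, for the compounds shown here, pyrrolidin-1-yl in place of butylamino on a carbonyl carbon gives an at least 2.1-fold lower number from compound 3 to compound 4 (0.32 log units; beyond the scatter), the first step that is printed as beyond the scatter, and an at least 2.1-fold lower number from compound 1 to compound 4 (0.32 log units; beyond the scatter) also clears it. Both of these steps start from a limit and not from a number: the limit of > 50000 nM in this assay, at which 2 of the 4 values shown sit. The step of a 1.4-fold lower number from compound 2 to compound 4 (0.16 log units; within the scatter) lies within the scatter, so the two ring amides are not told apart although their chains differ, and across the four compounds only those with a ring amine on the carbonyl give a number.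

The ring and the loss of the amide hydrogen arrive together in these compounds, so their shares remain unseparated. A dimethylamino amide on the same chain would bear on that question, and a morpholin-4-yl amide on the chain of compound 4 would bear on the part played by the chain.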